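Swapping the halogen-bearing benzyl group in a weak series

The compounds below may be only part of what the source reports. "The series", "measured", "known", "first", "only" and "open" are said of these compounds alone.

Within the data shown here, the three compounds measured so far share a common core with a hindered phenol, an amide link and a benzyl-substituted saturated amine ring, and all three are weak inhibitors. In an assay on isolated protein for inhibition of Amine oxidase [flavin-containing] A (Homo sapiens), read by fluorescence, with stated times of 15 min and 20 min (a lower number here means a stronger inhibitor, a higher number a weaker inhibitor), compound 3 `CC(C)(C)c1cc(/C=C/C(=O)NCCC2CCN(Cc3ccccc3F)CC2)cc(C(C)(C)C)c1O` gives 60200 nM. Compound 3 sits close to its neighbours: compound 2 `CC(C)(C)c1cc(/C=C/C(=O)NCC2CCN(Cc3ccccc3)CC2)cc(C(C)(C)C)c1O` gives 48400 nM, and compound 1 `CC(C)(C)c1cc(CCC(=O)NC2CCN(Cc3ccccc3)CC2)cc(C(C)(C)C)c1O` gives 90200 nM, and neither gap from compound 3 exceeds the usual scatter of repeated measurements, so the three cannot be ranked.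

Compound 4 `CC(C)(C)c1cc(/C=C/C(=O)NCCC2CCN(Cc3ccc(Br)cc3)CC2)cc(C(C)(C)C)c1O` has not yet been measured. It differs from compound 3 in one place: 4-bromophenyl in place of 2-fluorophenyl on a saturated chain carbon bound to an amine nitrogen in a ring. Among the measured compounds shown here, no measured pair in this set shows the effect of such a swap, so there is no step to lean on.

With every measured difference sitting inside the scatter, the expected step from compound 3 to compound 4 is a 1.0-fold lower number from compound 3 to compound 4 (0.00 log units; within the scatter), meaning no change beyond the scatter. Compound 4 is therefore estimated at 60000 nM, within a range from 25000 nM to 150000 nM.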

Compound 4, half-maximal inhibitory concentration: 73200 nM
For compound 4 the middle estimate is 1.2-fold (0.09 log units) below the measured one; the range from low to high includes it.
By their numbers in this assay, from the lowest: compounds 2, 3, 4 and 1 (each within the scatter of the next).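

Among these compounds, this is the first pair in the set that differs in one place only, with 4-bromophenyl in place of 2-fluorophenyl on a saturated chain carbon bound to an amine nitrogen in a ring. In this assay the swap gives a 1.2-fold higher number from compound 3 to compound 4 (0.08 log units; within the scatter) and so compound 3 and compound 4 cannot be told apart, which shows that this position accepts either halogen-bearing group with the same heavy-atom count and no measurable difference. No measurement here accounts for that result.

The swap alters the halogen and its place on the aromatic ring together, so 4-fluorophenyl or 2-bromophenyl would be needed to separate the two. Going by these compounds, whether a non-halogen group on that ring, such as a methoxy group or a carboxylic acid, would shift the number beyond the scatter also remains open.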